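Replacing Chloro with Nitro: Compound 2 to Compound 3

This account rests on a few compounds, and the source may have more. Where it says the series, first, only, none or still open, it means among the compounds named here.

In a functional assay on CCRF-CEM cells (Homo sapiens) for cytotoxicity, read by MTT assay, with a stated time of 96 h (on this read-out lower numbers stand for higher toxicity in this test and higher numbers for lower toxicity in this test), compound 1 `FC(F)(F)c1cccc(NC(=S)Nc2ccc(I)cc2)c1` gives 8000 nM and compound 2 `FC(F)(F)c1cccc(NC(=S)Nc2ccc(Cl)cc2)c1` gives 12000 nM, so the two values lie within the scatter of each other. Compound 3 `O=[N+]([O-])c1ccc(NC(=S)Nc2cccc(C(F)(F)F)c2)cc1` has not yet been measured. It differs from compound 2 by one change, nitro in place of chloro on an aromatic carbon, para to a large group. For the measured compounds named here, only one measured step bears on this place, a 1.5-fold higher number from compound 1 to compound 2 (0.18 log units; within the scatter), and it swapped iodo for chloro without leaving the scatter. Going by the values given here, no measured compound carries nitro, so the evidence for this change is thin. On that basis, no step beyond the scatter is expected in this assay, and the estimated step is a 1.2-fold lower number from compound 2 to compound 3 (0.08 log units; within the scatter). For compound 3 the estimated value is 10000 nM, with an expected range from 4000 nM to 25000 nM.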

Compound 3, half-maximal cytotoxic concentration: 8700 nM
The estimate for compound 3 lay 1.1-fold (0.06 log units) above the measured number, and the stated range covers the measured number.
By their numbers in this assay, from the lowest: compounds 1, 3 and 2 (each within the scatter of the next).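

For the compounds shown here, compound 3 carries nitro on the aromatic carbon para to a large group, where the earlier compounds carry iodo or chloro, and in this assay the change gives a 1.4-fold lower number from compound 2 to compound 3 (0.14 log units; within the scatter) and also a 1.1-fold higher number from compound 1 to compound 3 (0.04 log units; within the scatter). Both steps lie within the scatter, so chloro, iodo and nitro cannot be told apart at this position in this test, and replacing a halogen with nitro, a group of a different kind, does not move the number beyond the scatter. Nothing shown here offers a measured explanation for this result.

Going by these compounds, whether an amine, a carboxylic acid or a longer chain at this place would stay within the same scatter remains open. The trifluoromethyl group is the same in all the compounds shown, so what a change there would do is open too.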